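Aryl change on the amidoxime series: compound 1 to compound 4

The source may report more compounds than this note shows. Statements on the series, on what has been measured and on what is new or still open speak of the compounds shown alone.

Compound 1 `NS(=O)(=O)CC(=O)NCCSc1nonc1/C(=N/O)Nc1cccc(Cl)c1` is the reference of the series. In an assay for inhibition of Indoleamine 2,3-dioxygenase 1 (Homo sapiens), read by fluorescence, with a stated time of 1 h (on this read-out higher numbers stand for weaker inhibition and lower numbers for stronger inhibition), compound 1 gives 21 nM, the lowest number of the three measured; the nearest is compound 2 `NS(=O)(=O)NCCSc1nonc1/C(=N/O)Nc1ccc(F)c(Br)c1` with 130 nM, and the furthest is compound 3 `CSc1nonc1/C(=N/O)Nc1ccc(F)c(Br)c1` with 560 nM. For the measured compounds named here, the one single-point step measured so far, a 4.3-fold higher number from compound 2 to compound 3 (0.63 log units; beyond the scatter), concerns the chain on the sulfur and not the aryl ring. Compound 1 and compound 2 differ both in the chain and in the aryl ring, so their two values alone do not separate the two contributions.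

Compound 4 `NS(=O)(=O)CC(=O)NCCSc1nonc1/C(=N/O)Nc1ccc(F)c(C(F)F)c1` keeps the chain of compound 1 and changes only the aryl ring: 3-(difluoromethyl)-4-fluorophenyl in place of 3-chlorophenyl on an amine nitrogen. Going by the values given here, no measured step in this set bears on an aryl change of this kind, so there is no direct precedent for its size or direction. The chain shared by compound 1 and compound 4 is the one paired with the lowest number measured, which is the only anchor for an expectation.

For compound 4 a step of a 1.7-fold higher number from compound 1 to compound 4 (0.22 log units; within the scatter) is expected, near the scatter and with no firm direction. The estimate for compound 4 in this assay is 35 nM, with a range of 12 nM to 120 nM.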

Compound 4, half-maximal inhibitory concentration: 73 nM
Compound 4: middle estimate off by 2.1-fold (0.32 log units), on the low side; low and high end bracket the measured number.
By their numbers in this assay, from the lowest: compound 1; then compounds 4 and 2 (each within the scatter of the next); then compound 3.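

In this assay, the aryl ring on the amine nitrogen proves to be a place that moves the number on its own: with the chain on the sulfur held fixed, 3-(difluoromethyl)-4-fluorophenyl in place of 3-chlorophenyl gives a 3.5-fold higher number from compound 1 to compound 4 (0.54 log units; beyond the scatter), towards weaker inhibition. For the compounds shown here, until now the only single-place step lay in the chain, a 4.3-fold higher number from compound 2 to compound 3 (0.63 log units; beyond the scatter), and the aryl contribution could not be separated; the new step shows that the aryl ring also counts, while the two groups match in hydrogen-bond donors, acceptors and net charge and differ in heavy atoms and in their halogens. Nothing measured here explains the change in the number.

From the compounds shown here alone, compound 4 differs from compound 1 in both the difluoromethyl group replacing the chlorine and the added fluorine, so the share of each in the step remains open. A ring keeping the chlorine and adding only the fluorine would separate the two, and a trifluoromethyl group or a nitrile in place of the difluoromethyl group would show how far this place tolerates other substituents.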